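A few compounds are considered here, and "the series" means these few. Any claim that something is new, unique, unknown or untested is made for them only; others in the source may bear on it.

In this study a functional assay on CHO-K1 cells for antagonist activity at adenosine receptor A1 (Homo sapiens), read by a beta-galactosidase reporter and cAMP accumulation, with stated times of 15 min and 6 h (on this read-out higher numbers stand for weaker inhibition and lower numbers for stronger inhibition), was run on three close analogues. Compound 1 `N#Cc1cccc(-c2nc(N)c3cc(Cc4ccccc4Cl)sc3n2)c1` gives 24.8 nM in this assay. Compound 2 `C=C(c1ccccc1)c1cc2c(N)nc(-c3cccc(C#N)c3)nc2s1` does not give a number in this assay but only its limit, > 1000 nM. That compound 2 sits at this limit is recorded as the limit of > 1000 nM in this assay, at which 1 of the 2 values shown sits. The one measured step, an at least 40-fold higher number from compound 1 to compound 2 (1.60 log units; beyond the scatter), is large and beyond the scatter, so compound 2 stands at the weak end of the numbers shown, known only as a limit.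

Compound 3 `N#Cc1cccc(-c2nc(N)c3cc(C4(c5ccccc5)CC4)sc3n2)c1` differs from compound 2 by 1-phenylcyclopropyl in place of 1-phenylethenyl on an aromatic carbon. Among the compounds with values here, no measured step covers this exchange; the only step available, an at least 40-fold higher number from compound 1 to compound 2 (1.60 log units; beyond the scatter), concerns a different group and so cannot be transferred to it. Given that the phenyl group on a branched carbon remains in compound 3, compound 3 is expected to stay close to compound 2, the step that the limit leaves unreadable from compound 2 to compound 3 being estimated as none beyond the scatter. The estimate for compound 3 in this assay is 1500 nM, with a range from 300 nM to 8000 nM, and with a fair chance that this assay again reports only a limit.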

Compound 3, inhibition constant: > 610 nM
Compound 3 gave a limit, no number; the forecaster's own chance of this, stated with the estimate: 60%; the middle value is on the limit's open side.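

In this assay compound 3 is recorded only as a limit, > 610 nM, and not as a number. Replacing 2-chlorobenzyl with 1-phenylcyclopropyl, on the aromatic carbon next to the ring sulfur, gives an at least 24-fold higher number from compound 1 to compound 3 (1.39 log units; beyond the scatter), so the large loss seen earlier with 1-phenylethenyl is not confined to that one group or to its double bond outside aromatic rings: among these three compounds, both groups with the phenyl on a branched carbon lie well on the weak side of compound 1, and neither goes against this. Compound 2 and compound 3 are both limits, so the step between them cannot be read, and the data do not rank 1-phenylcyclopropyl against 1-phenylethenyl.

The compounds shown do not separate the role of the branched carbon from that of the chlorine, since each of the two exchanges changes both at once. On these data alone, whether a plain benzyl, a 1-phenylethyl group or a 2-chlorophenyl-bearing cyclopropyl at this place would return a number in this assay, and how an amine or a carboxylic acid on the phenyl would read there, remains open.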